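Shortening the chain of compound 2

The source may report more compounds than this note shows. Statements on the series, on what has been measured and on what is new or still open speak of the compounds shown alone.

In a functional assay on B16-F10 cells (Mus musculus) for antiproliferative activity, read by MTT assay, with a stated time of 72 h (on this read-out higher numbers stand for weaker inhibition and lower numbers for stronger inhibition), compound 2 `CCCCCCCCCCCCNC[C@@H]1OC[C@H](N)[C@H]1O` gives 58100 nM, the higher of the two actual numbers, while compound 3 `CCCCCCCCCCCCNC[C@@H]1OC[C@H](N)[C@@H]1O` gives 10700 nM. Compound 1 `CCCCCCCCNC[C@@H]1OC[C@H](N)[C@@H]1O` gives > 128000 nM, which is a limit of the assay and not a number. Compound 4 `CCCCCCCCCCCNC[C@@H]1OC[C@H](N)[C@H]1O` changes compound 2 by hydrogen in place of methyl on a saturated chain carbon, ten or more bonds along the chain from an amine nitrogen, hydrogen in place of methyl on a saturated chain carbon. The closest guide is the large at least 11-fold lower number from compound 1 to compound 3 (1.07 log units; beyond the scatter), where butyl replaces hydrogen. The modest 5.4-fold lower number from compound 2 to compound 3 (0.73 log units; beyond the scatter) comes with the fact that compounds 2 and 3 differ only in the configuration as drawn, so it does not bear on chain length. Losing only methyl should matter less than gaining butyl. The expected step is a 1.7-fold higher number from compound 2 to compound 4 (0.24 log units; within the scatter), a small move towards weaker inhibition. For compound 4 the estimated value is 100000 nM, with an expected range of 55000 nM to 190000 nM.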

Compound 4, half-maximal inhibitory concentration: 88800 nM
Beside the measured number, compound 4's estimate is 1.1-fold (0.05 log units) above it; measured number inside the range.
By their numbers in this assay, from the lowest: compound 3; then compounds 2 and 4 (each within the scatter of the next). At a limit, above all of these: compound 1.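

Hydrogen in place of methyl on a saturated chain carbon gives a 1.5-fold higher number from compound 2 to compound 4 (0.18 log units; within the scatter) in this assay. So this single-carbon change to the chain of compound 2 cannot be told from repeat-measurement scatter, unlike the larger butyl change seen earlier, which was made in the other drawn configuration. The data shown offer no explanation for this step.

Going by these compounds, whether the same change would behave alike on compound 3 remains open. So does whether a longer chain would give a lower number.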